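The compounds below may be only part of what the source reports. "The series", "measured", "known", "first", "only" and "open" are said of these compounds alone.

Among the measured compounds shown here, in a functional assay on PC-3 cells (Homo sapiens) for cytotoxicity, read by MTT assay, with a stated time of 72 h (a lower number here means a stronger inhibitor, a higher number a weaker inhibitor), compound 3 `[O-][n+]1nc(NCOC2CCCCC2)[n+]([O-])c2ccccc21` gives 3250 nM, the lowest of the three numbers measured so far. Compound 1 `[O-][n+]1nc(NCOCc2ccc(C(F)(F)F)cc2)[n+]([O-])c2ccccc21` gives 7650 nM and compound 2 `CCCCOCNc1n[n+]([O-])c2ccccc2[n+]1[O-]` gives 14700 nM, both beyond the scatter above compound 3. For the measured compounds named here, the one single-point step recorded, a 4.5-fold lower number from compound 2 to compound 3 (0.66 log units; beyond the scatter), shows that a ring in place of a straight chain on the oxygen lowered the number modestly. Compound 4 `CC(C)CCOCNc1n[n+]([O-])c2ccccc2[n+]1[O-]` differs from compound 3 by isopentyl in place of cyclohexyl on an oxygen on a saturated carbon, an open chain again, which partly undoes that step. Compound 4 is therefore expected to give a higher number than compound 3, by a step of a 1.8-fold higher number from compound 3 to compound 4 (0.27 log units; within the scatter), smaller than the earlier one. The estimated value of compound 4 in this assay is 6000 nM, within 2500 nM to 14000 nM.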

Compound 4, half-maximal inhibitory concentration: 11100 nM
The estimate for compound 4 lay 1.9-fold (0.27 log units) below the measured number; the range from low to high includes it.
By their numbers in this assay, from the lowest: compound 3; then compounds 1, 4 and 2 (each within the scatter of the next).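

In this assay, a 3.4-fold higher number from compound 3 to compound 4 (0.53 log units; beyond the scatter) shows that the gain seen with cyclohexyl does not carry over to a longer open chain, even one that is branched and close to cyclohexyl in size. With a 1.3-fold lower number from compound 2 to compound 4 (0.12 log units; within the scatter), the added methyl does not separate isopentyl from butyl, so among compounds 2, 3 and 4 only the ring stands apart. The compounds shown leave open whether a smaller ring such as cyclopentyl would keep the low number of compound 3, or how an amine at the end of the chain would fare. Nothing available here explains why the ring differs from the open chains.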